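The source may report more compounds than this note shows. Statements on the series, on what has been measured and on what is new or still open speak of the compounds shown alone.

In an ADME assay on the whole organism for pharmacokinetics, with Rattus norvegicus as the target, at a dose of 1 mg/kg by the oral route (a higher number here means more compound in the circulation at the dose given, a lower number less compound in the circulation), compound 1 `CC(C)CC1(O)CCN(C(=O)Nc2cc(Oc3ccc(F)cc3)cc(Oc3ccc(CC(=O)O)cc3)c2)CC1` gives 237 nM, the lower of the two numbers recorded so far. Compound 2 `CC(C)CC1(O)CN(C(=O)Nc2cc(Oc3ccc(F)cc3)cc(Oc3ccc(C(C)(C)C(=O)O)cc3)c2)C1` gives 738 nM, and that gap lies beyond the usual scatter. Compound 3 `CC(C)CC1(O)CCN(C(=O)Nc2cc(Oc3ccc(F)cc3)cc(Oc3ccc(C(=O)O)cc3)c2)CC1` is not yet measured. It differs from compound 1 in one place, (carboxy in place of carboxymethyl on an aromatic carbon), that is, carboxy in place of carboxymethyl on an aromatic carbon. Among the measured compounds shown here, no measured pair shows this change, so its effect can only be guessed as small, in either direction or none beyond the scatter. Compound 3 is therefore expected to give about 300 nM, with a range from 100 nM to 900 nM. The estimated step is a 1.3-fold higher number from compound 1 to compound 3 (0.10 log units; within the scatter).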

Compound 3, maximal plasma concentration: 34.5 nM
Beside the measured number, compound 3's estimate is 8.7-fold (0.94 log units) above it; measured number below the stated range.
By their numbers in this assay, from the lowest: compound 3; then compound 1; then compound 2.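

In this assay, this position proves sensitive to the length of the acid chain: carboxy in place of carboxymethyl on the aromatic carbon gives a 6.9-fold lower number from compound 1 to compound 3 (0.84 log units; beyond the scatter). Removing one carbon from this group, with the rest of compound 1 unchanged, is therefore enough to move the number beyond the usual scatter. No information here explains the drop.

From the compounds shown here alone, whether a longer chain, such as carboxyethyl, would raise the number remains open, as does the effect of an amine here. Compound 2 differs from compound 1 in more than one place, so it cannot settle either question.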